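Trimming the Benzyloxy Group of Compound 1

The source may hold more compounds than are shown below. What is called first, only, known or untested is meant among the compounds shown, and "the series" means these compounds.

Compound 1 `CN(C)CCNc1ccnc2cc(OCc3ccccc3)ccc12`: 1250 nM in a functional assay on BGC-823 cells (Homo sapiens) for cytotoxicity, read by MTT assay, with a stated time of 48 h; on this read-out lower numbers stand for stronger inhibition and higher numbers for weaker inhibition
Compound 2 `Clc1ccnc2cc(OCc3ccccc3)ccc12`: 5170 nM in this assay

Compound 1 stands lowest of the two numbers. Going by the values given here, the only measured step, a 4.1-fold higher number from compound 1 to compound 2 (0.62 log units; beyond the scatter), concerns chloro in place of (2-(dimethylamino)ethyl)amino on an aromatic carbon. Compound 3 `CCOc1ccc2c(NCCN(C)C)ccnc2c1` awaits measurement and differs from compound 1 by methyl in place of phenyl on a saturated chain carbon bound to an oxygen on an aromatic ring. Among the compounds with values here, no measured step bears on this benzyloxy to ethoxy change, so no step beyond the scatter is predicted with confidence, and the range is kept wide. Compound 3 is expected to give 2500 nM in this assay, between 800 nM and 8000 nM. This estimate corresponds to an expected 2.0-fold higher number from compound 1 to compound 3 (0.30 log units; within the scatter).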

Compound 3, half-maximal inhibitory concentration: 2520 nM
Beside the measured number, compound 3's estimate is 1.0-fold (0.00 log units) below it; the measured number falls inside the stated range.
By their numbers in this assay, from the lowest: compounds 1 and 3 (each within the scatter of the next); then compound 2.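

In this assay, methyl in place of phenyl on this saturated chain carbon gives a 2.0-fold higher number from compound 1 to compound 3 (0.30 log units; within the scatter). The earlier step concerned only the (2-(dimethylamino)ethyl)amino group; this one shows that, with that group kept, benzyloxy can be cut back to ethoxy, losing the whole aromatic ring, without a step beyond the scatter. Nothing available here explains this result. On these data alone, whether a longer chain such as propoxy would read the same remains open. So does the effect of an amine or a carboxylic acid at the end of this chain.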